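The source may report more compounds than this note shows. Statements on the series, on what has been measured and on what is new or still open speak of the compounds shown alone.

Measured so far in a functional assay on MCF7 cells (Homo sapiens) for antiproliferative activity, read by sulforhodamine B assay, with a stated time of 48 h; on this read-out higher numbers stand for weaker inhibition of growth and lower numbers for stronger inhibition of growth:
compound 1 `O=C(NCc1cn(Cc2ccc(Cl)cc2)nn1)c1cn(-c2ccccc2)nc1-c1ccc(F)cc1` gives 130 nM;
compound 2 `COc1ccc(-c2nn(-c3ccccc3)cc2C(=O)NCc2cn(Cc3ccc(F)cc3)nn2)cc1` gives 460 nM;
compound 3 `COc1ccc(-c2nn(-c3ccccc3)cc2C(=O)NCc2cn(Cc3ccc(Cl)cc3)nn2)cc1` gives 2900 nM.

Compound 3 has the highest number of the three. The nearest is compound 2, since a 6.3-fold higher number from compound 2 to compound 3 (0.80 log units; beyond the scatter), and the furthest is compound 1, since a 22-fold higher number from compound 1 to compound 3 (1.35 log units; beyond the scatter). Compound 4 `COc1ccc(-c2nn(-c3ccccc3)cc2C(=O)NCc2cn(Cc3ccc(OC)c(OC)c3)nn2)cc1` differs from compound 3 by 3,4-dimethoxyphenyl in place of 4-chlorophenyl on a saturated chain carbon bound to an aromatic nitrogen. Among the measured compounds shown here, of the two measured steps only a 6.3-fold higher number from compound 2 to compound 3 (0.80 log units; beyond the scatter) bears on this site, and it is modest; no measured compound carries methoxy groups on that ring. No firm direction follows, so a step in this assay within or only just beyond the scatter is expected. For compound 4 the estimate is 2000 nM, between 500 nM and 8000 nM, which means an expected 1.5-fold lower number from compound 3 to compound 4 (0.16 log units; within the scatter).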

Compound 4, concentration for 50% growth inhibition: > 100000 nM
Compound 4: only a limit was reported; the forecaster's own chance of this, stated with the estimate: 10%; middle value at least 50-fold (1.69 log units) away from the limit.
By their numbers in this assay, from the lowest: compound 1; then compound 2; then compound 3. At a limit, above all of these: compound 4.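

Compound 4 gives a limit and not a number: the limit of > 100000 nM in this assay, at which 1 of the 4 values shown sits. Until now this position had shown only a chloro-for-fluoro change, a 6.3-fold higher number from compound 2 to compound 3 (0.80 log units; beyond the scatter), whereas 3,4-dimethoxyphenyl in place of 4-chlorophenyl gives an at least 34-fold higher number from compound 3 to compound 4 (1.53 log units; beyond the scatter), and in place of 4-fluorophenyl gives an at least 210-fold higher number from compound 2 to compound 4 (2.33 log units; beyond the scatter). In this assay, the ring on this saturated chain carbon can therefore decide whether the series keeps a measurable value at all.

Going by these compounds, whether a single methoxy group on that ring is enough for this loss stays open. So does the outcome with an amine or a carboxylic acid there, or with this ring on the core of compound 1.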